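Aryl for sulfonyl on a piperazine nitrogen

The source may hold more compounds than are shown below. What is called first, only, known or untested is meant among the compounds shown, and "the series" means these compounds.

Measured compounds:
compound 1 `CCOC(=O)N1CCN(c2ccc3nnc(-c4cccc(C)c4)n3n2)CC1`: 1 ug/mL
compound 2 `Cc1cccc(-c2nnc3ccc(N4CCN(S(C)(=O)=O)CC4)nn23)c1`: 10.8 ug/mL

Compound 2 `Cc1cccc(-c2nnc3ccc(N4CCN(S(C)(=O)=O)CC4)nn23)c1` gives 10.8 ug/mL in a functional assay for inhibition, read by spectrophotometry, with a stated time of 60 min (a higher number here means a weaker inhibitor, a lower number a stronger inhibitor), the higher of the two numbers; compound 1 `CCOC(=O)N1CCN(c2ccc3nnc(-c4cccc(C)c4)n3n2)CC1` gives 1 ug/mL in this assay. Among the measured compounds shown here, the one measured step, an 11-fold higher number from compound 1 to compound 2 (1.03 log units; beyond the scatter), shows that the group on the ring amine nitrogen matters in this assay. Compound 3 `COc1ccc(N2CCN(c3ccc4nnc(-c5cccc(C)c5)n4n3)CC2)cc1` has not yet been measured. It differs from compound 2 in one place: 4-methoxyphenyl in place of methylsulfonyl on an amine nitrogen in a ring. For the measured compounds named here, no measured step puts an aromatic group at this position, so the direction of the change is open. Going by the values given here, since the one step between compound 1 and compound 2 was large, a step of similar size in either direction would not surprise, and an intermediate outcome seems as likely as any. Compound 3 is therefore estimated at 3.5 ug/mL, within 0.8 ug/mL to 15 ug/mL, which means an expected step of a 3.1-fold lower number from compound 2 to compound 3 (0.49 log units; beyond the scatter).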

Compound 3, half-maximal inhibitory concentration: 45.9 ug/mL
For compound 3 the middle estimate is 13-fold (1.12 log units) below the measured one; measured number above the stated range.
By their numbers in this assay, from the lowest: compound 1; then compound 2; then compound 3.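

In this assay an aromatic group on the amine nitrogen in the ring gives a 4.3-fold higher number from compound 2 to compound 3 (0.63 log units; beyond the scatter) and so weakens inhibition further than methylsulfonyl does. Against the ethoxycarbonyl group the change gives a 46-fold higher number from compound 1 to compound 3 (1.66 log units; beyond the scatter) and is the widest step measured at this position, which makes compound 3 the weakest of the three. The nitrogen therefore tolerates neither replacement of ethoxycarbonyl well, and the larger 4-methoxyphenyl group, with 8 heavy atoms and one six-membered aromatic ring, does not recover what methylsulfonyl lost.

From the compounds shown here alone, it remains open whether the loss belongs to the aromatic ring or to its methoxy group, which a plain phenyl group would separate, and whether an acetyl group or a free ring amine would come near ethoxycarbonyl. No other measurement bears on why the three groups fall in this order.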